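Extending the ether chain of compound 2 with a hydroxymethyl

This account rests on a few compounds, and the source may have more. Where it says the series, first, only, none or still open, it means among the compounds named here.

Measured compounds:
compound 1, `Cc1cc(OC(C)C)cc(C)c1-c1cccc(COc2ccc(OCC(=O)O)c(F)c2)c1` — in a physicochemical assay for lipophilicity, using the shake flask method, in phosphate buffer, measured as octanol-water partition, with a stated time of 24 h, at pH 7.4, tested at 100 uM (on this read-out higher numbers stand for higher lipophilicity and lower numbers for lower lipophilicity), compound 1 gives "not determined" (no result reported)
compound 2, `CCOc1cc(C)c(-c2cccc(COc3ccc(OCC(=O)O)c(F)c3)c2)c(C)c1` — 3.48
compound 3, `COc1cc(C)c(-c2cccc(COc3ccc(OCC(=O)O)c(F)c3)c2)c(C)c1` — 3.2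

Going by the values given here, compound 2 carries the higher of the two numbers that were obtained in this assay, but its only neighbour, compound 3, sits a number 0.28 log units lower from compound 2 to compound 3 (within the scatter), so the two cannot be told apart on this read-out. Compound 1 stands beside them without a result.

The step to compound 4, `Cc1cc(OCCCO)cc(C)c1-c1cccc(COc2ccc(OCC(=O)O)c(F)c2)c1`, is hydroxymethyl in place of hydrogen on a saturated chain carbon, two bonds along the chain from an oxygen on an aromatic ring. Among the compounds with values here, of the measured steps, only the one from compound 2 to compound 3 touches the same chain, and it removed a methyl rather than adding a group: it was a number 0.28 log units lower from compound 2 to compound 3 (within the scatter). Within the data shown here, no measured step puts a hydroxymethyl onto this chain, so nothing here shows directly how this assay responds to that change. On the usual behaviour of such a change, an account of compound 4 would expect a downward step, a number 0.58 log units lower from compound 2 to compound 4 (beyond the scatter), larger than the scatter. Compound 4 is therefore estimated at 2.9, with a range from 2.4 to 3.4.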

Compound 4, distribution coefficient: 2.73
Compound 4: middle estimate off by 0.17 log units, on the high side; the measured number falls inside the stated range.
By their numbers in this assay, from the lowest: compound 4; then compounds 3 and 2 (each within the scatter of the next).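

In this assay, the ether chain now shows a step beyond the scatter: the change to the 3-hydroxypropoxy chain gives a number 0.75 log units lower from compound 2 to compound 4 (beyond the scatter) and, measured against the shorter chain, a number 0.47 log units lower from compound 3 to compound 4 (beyond the scatter). The earlier pair had shown only a number 0.28 log units lower from compound 2 to compound 3 (within the scatter), which left open whether this read-out responded to changes on this chain at all. Both new steps run in the same direction and are modest in size, but nothing among the results offers an explanation for the fall.

Compound 4 differs from compound 2 by both a longer chain and a hydroxyl-bearing group, and the compounds shown do not separate these two parts of the change; a plain propoxy chain would bear directly on that question. Nor do they show whether a 3-aminopropoxy or 3-methoxypropoxy chain would give a similar step, or whether a 4-hydroxybutoxy chain would take the number further in the same direction.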